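Swapping the aryl end of the hydrazone on a shared core

This account rests on a few compounds, and the source may have more. Where it says the series, first, only, none or still open, it means among the compounds named here.

Three compounds were measured in a functional assay on MKN-45 cells (Homo sapiens) for cytotoxicity, read by MTT assay, with a stated time of 72 h; on this read-out higher numbers stand for weaker inhibition and lower numbers for stronger inhibition:
compound 1 `COc1ccc(OC)c(/C=N/NC(=O)Nc2ccc(Oc3ccnc(-c4nncn4CCN(C)C)c3)c(F)c2)c1` gives 1510 nM;
compound 2 `CN(C)CCn1cnnc1-c1cc(Oc2ccc(NC(=O)N/N=C/c3c[nH]c4ccccc34)cc2F)ccn1` gives 790 nM;
compound 3 `Cc1cc(/C=N/NC(=O)Nc2ccc(Oc3ccnc(-c4nncn4CCN(C)C)c3)c(F)c2)cc(C)c1O` gives 1510 nM.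

Compound 1 stands level with compound 3 at the digits shown, the two together the highest numbers of the three; the step of a 1.9-fold lower number from compound 1 to compound 2 (0.28 log units; within the scatter) and the step of no change at the digits printed from compound 1 to compound 3 (within the scatter) are both within the scatter, as is a 1.9-fold higher number from compound 2 to compound 3 (0.28 log units; within the scatter). Compound 4 `CN(C)CCn1cnnc1-c1cc(Oc2ccc(NC(=O)N/N=C/c3ccc(F)cc3)cc2F)ccn1` differs from compound 1 by 4-fluorophenyl in place of 2,5-dimethoxyphenyl on a carbon with a double bond to nitrogen. Both measured changes at this same carbon with a double bond to nitrogen stayed within the scatter, so the expected step is a 1.3-fold lower number from compound 1 to compound 4 (0.10 log units; within the scatter), none beyond the scatter. Compound 4 is therefore estimated to give 1200 nM in this assay, with a range from 500 nM to 3000 nM.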

Compound 4, half-maximal inhibitory concentration: 1030 nM
Compound 4: the middle estimate sits 1.2-fold (0.07 log units) above what was measured; measured number inside the range.
By their numbers in this assay, from the lowest: compounds 2, 4, 1 and 3 (each within the scatter of the next).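

In this assay 4-fluorophenyl, which has fewer heavy atoms than 2,5-dimethoxyphenyl and no hydrogen-bond acceptors, stays within the scatter of all three earlier groups on this carbon with a double bond to nitrogen: against 2,5-dimethoxyphenyl (a 1.5-fold lower number from compound 1 to compound 4 (0.17 log units; within the scatter)), against 4-hydroxy-3,5-dimethylphenyl (a 1.5-fold lower number from compound 3 to compound 4 (0.17 log units; within the scatter)) and against 1H-indol-3-yl (a 1.3-fold higher number from compound 2 to compound 4 (0.12 log units; within the scatter)). The four groups therefore cannot be told apart on this read-out, even with a group carrying neither oxygen nor nitrogen now among them. No evidence is available to explain this result.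

The compounds shown leave open whether an amine or a carboxylic acid on the aromatic ring, or a longer chain in its place, would move the number beyond the scatter.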